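Moving the Pyrazole Attachment Point from Compound 1

The source may report more compounds than this note shows. Statements on the series, on what has been measured and on what is new or still open speak of the compounds shown alone.

Going by the values given here, compound 1 `C[C@@H]1CCCN1c1c(C#N)c2c(N)nc(Nc3ccn(C)n3)cc2n1C` gives 6 nM in an assay on isolated protein for binding affinity to Leucine-rich repeat serine/threonine-protein kinase 2 (Homo sapiens), read by TR-FRET and LanthaScreen, with a stated time of 2 h (a lower number here means a stronger inhibitor, a higher number a weaker inhibitor), the lowest of the two numbers measured so far; compound 2 `Cn1c(-c2cccc(F)c2F)c(C#N)c2c(N)ncnc21` gives 14 nM in this assay, a gap beyond the usual scatter. Compound 3 `C[C@@H]1CCCN1c1c(C#N)c2c(N)nc(Nc3cnn(C)c3)cc2n1C` keeps the same atoms as compound 1 but joins them differently: 1-methyl-1H-pyrazol-4-yl in place of 1-methyl-1H-pyrazol-3-yl on a nitrogen on an aromatic ring. Among the compounds with values here, no measured pair shows this change, so its size is unknown. The step of a 2.5-fold higher number from compound 1 to compound 3 (0.40 log units; beyond the scatter) is estimated to be a modest weakening, only a little beyond the scatter. Compound 3 is therefore expected to give about 15 nM, within 4 nM to 60 nM.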

Compound 3, inhibition constant: 538 nM
Compound 3: middle estimate off by 36-fold (1.55 log units), on the low side; the whole stated range lies below it.
By their numbers in this assay, from the lowest: compound 1; then compound 2; then compound 3.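

With the same atoms on a nitrogen on an aromatic ring, the step of a 90-fold higher number from compound 1 to compound 3 (1.95 log units; beyond the scatter) in this assay shows that the two pyrazole attachments are far from interchangeable. Going by these compounds alone, this is the first step read at this position, and it is large, so the attachment point of the ring matters strongly here, in the setting of compound 1. Nothing measured bears on the cause of this loss.

From the compounds shown here alone, how a 1-methyl-1H-pyrazol-5-yl group, a pyrazole without the methyl, or a phenyl ring would fare on this nitrogen stays open. Going by these compounds, whether the 1-methyl-1H-pyrazol-3-yl group itself is needed, or only tolerated, also stays open.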